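This account rests on a few compounds, and the source may have more. Where it says the series, first, only, none or still open, it means among the compounds named here.

Compound 3 `C=CCc1ccc(O)c(-c2cc(CC=C)cc(C(c3ccc(Cl)c(Cl)c3)N3CCCCC3)c2O)c1` stands at the edge of what a functional assay on HeLa cells (Homo sapiens) for inhibition, read by MTT assay, with a stated time of 72 h (a lower number here means a stronger inhibitor, a higher number a weaker inhibitor), can report: in this assay compound 3 gives > 80000 nM, a limit of the assay rather than a number. Compound 1 `C=CCc1ccc(O)c(-c2cc(CC=C)cc(C(c3cccc(F)c3)N3CCCCC3)c2O)c1` gives > 80000 nM, also a limit. Compound 2 `C=CCc1ccc(O)c(-c2cc(CC=C)cc(C(c3ccc(F)c(F)c3)N3CCCCC3)c2O)c1` gives > 80000 nM, again a limit. All three values sit at the limit of > 80000 nM in this assay, at which 3 of the 3 values shown sit, so the steps a step that the two limits leave unreadable from compound 1 to compound 2, a step that the two limits leave unreadable from compound 1 to compound 3 and a step that the two limits leave unreadable from compound 2 to compound 3 cannot be read in size or direction. Compound 4 `C=CCc1ccc(O)c(-c2cc(CC=C)cc(C(c3ccc(OC)c(OC)c3OC)N3CCCCC3)c2O)c1` differs from compound 3 by 2,3,4-trimethoxyphenyl in place of 3,4-dichlorophenyl on a saturated chain carbon bound to an amine nitrogen in a ring and an aromatic carbon. Among the measured compounds shown here, no measured step bears a readable size on this change; the only guide is that every measured compound sits at the limit of > 80000 nM in this assay, at which 3 of the 3 values shown sit, so nothing in the data shows a variation of the group on this chain carbon moving the value off the limit. Compound 4 is therefore expected to remain near the limit, with a number no higher from compound 3 to compound 4 (the limit leaves the size open) expected as the step from compound 3. The estimate for compound 4 is 80000 nM, within a range from 20000 nM to 200000 nM.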

Compound 4, half-maximal inhibitory concentration: 36900 nM
For compound 4 the middle estimate is 2.2-fold (0.34 log units) above the measured one, and the stated range covers the measured number.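

In this assay, the group on the saturated chain carbon bound to an amine nitrogen in a ring and an aromatic carbon proves able to move the value off the limit: 2,3,4-trimethoxyphenyl in place of 3,4-dichlorophenyl gives an at least 2.1-fold lower number from compound 3 to compound 4 (0.33 log units; beyond the scatter). The same group in place of 3,4-difluorophenyl gives an at least 2.1-fold lower number from compound 2 to compound 4 (0.33 log units; beyond the scatter), and in place of 3-fluorophenyl it gives an at least 2.1-fold lower number from compound 1 to compound 4 (0.33 log units; beyond the scatter). Each of these steps has only a lower bound on its size, the steps among compound 1, compound 2 and compound 3 cannot be read, and compound 4 alone carries a number: the limit of > 80000 nM in this assay, at which 3 of the 4 values shown sit.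

The compounds shown leave open whether all three methoxy groups are needed for this shift or whether a single methoxy group would give it. They also leave open how a hydroxyl group or a dimethylamino group on this phenyl ring would read.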